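Hydroxy to methoxy on the compound 1 scaffold

The compounds below may be only part of what the source reports. "The series", "measured", "known", "first", "only" and "open" are said of these compounds alone.

Measured in a functional assay on the whole organism (Hindlimb, strain albino) with Mus musculus as the target, in the maximal electroshock model, with a stated time of 0.5 h; on this read-out lower numbers stand for an effect already at smaller amounts and higher numbers for an effect only at larger amounts of compound:
- compound 1 `O=C(/C=C/c1ccc(O)cc1)Nc1nc2ccccc2s1`: 517 umol/kg
- compound 2 `O=C(/C=C/c1ccc(O)cc1)Nc1nc2ccc([N+](=O)[O-])cc2s1`: 382 umol/kg
- compound 3 `O=C(/C=C/OC1=CC=C1)Nc1nc2ccccc2s1`: 781 umol/kg

Compound 1 stands with no separation from either neighbour, as a 1.4-fold lower number from compound 1 to compound 2 (0.13 log units; within the scatter) and a 1.5-fold higher number from compound 1 to compound 3 (0.18 log units; within the scatter) show. Compound 4 `COc1ccc(/C=C/C(=O)Nc2nc3ccccc3s2)cc1` is still unmeasured in this assay. It differs from compound 1 by methyl in place of hydrogen on an oxygen on an aromatic ring, which is hydroxy to methoxy. Going by the values given here, no measured step makes this exact change, so the evidence is indirect. Both steps above are different changes, and neither leaves the scatter. From the compounds shown here alone, no step beyond the scatter is therefore expected, and the direction stays open. The estimated step is a 1.1-fold lower number from compound 1 to compound 4 (0.03 log units; within the scatter). For compound 4 the expected value is 480 umol/kg, with an estimated range from 240 umol/kg to 950 umol/kg.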

Compound 4, dose for half-maximal effect: 435 umol/kg
For compound 4 the middle estimate is 1.1-fold (0.04 log units) above the measured one; low and high end bracket the measured number.
By their numbers in this assay, from the lowest: compounds 2, 4, 1 and 3 (each within the scatter of the next, the first and the last beyond it).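

In this assay, hydroxy to methoxy gives a 1.2-fold lower number from compound 1 to compound 4 (0.08 log units; within the scatter), so methyl in place of hydrogen on this oxygen is now directly shown to stay within the scatter. The hydrogen on this oxygen is therefore not needed to keep the read-out in this range, which the steps at the other sites of the series could not show. Nothing available explains this result.

From the compounds shown here alone, whether an ethoxy group or a longer chain on this oxygen, or an amine in place of the hydroxy, stays in this range remains open. Also open, going by these compounds, is how methoxy behaves together with the nitro group of compound 2.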